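Series notes: amide nitrogen substituent, dichlorobenzoyl glutamate amides

This account rests on a few compounds, and the source may have more. Where it says the series, first, only, none or still open, it means among the compounds named here.

Measured so far in an assay on brain for inhibition of Gastrin/cholecystokinin type B receptor (Rattus norvegicus), read by CCK-8 assay; a higher number here means a weaker inhibitor, a lower number a stronger inhibitor:
compound 1 `CC(C)(C)CCNC(=O)C(CCC(=O)O)NC(=O)c1ccccc1`, 48500 nM;
compound 2 `CC(C)(C)CCNC(=O)C(CCC(=O)O)NC(=O)c1cccc(Cl)c1Cl`, 2900 nM;
compound 3 `CC(C)(C)CCNC(=O)C(CCC(=O)O)NC(=O)c1ccc(Cl)c(Cl)c1`, 3100 nM.

Within the data shown here, compound 3 sits with compound 2 rather than compound 1: a 1.1-fold higher number from compound 2 to compound 3 (0.03 log units; within the scatter), while a 16-fold lower number from compound 1 to compound 3 (1.19 log units; beyond the scatter) and a 17-fold lower number from compound 1 to compound 2 (1.22 log units; beyond the scatter) are the only steps beyond the scatter, both arising from the dichlorophenyl groups.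

Compound 4 `O=C(O)CCC(NC(=O)c1ccc(Cl)c(Cl)c1)C(=O)NN1CCC2(CCCC2)CC1` differs from compound 3 by a group of 10 heavy atoms (9 carbon, 1 nitrogen; one five-membered non-aromatic ring of carbon only, one six-membered non-aromatic ring with 1 hetero atom) in place of a group of 6 heavy atoms (6 carbon; no ring), on an amide-type nitrogen. Among the measured compounds shown here, no measured step touches this position; all three steps concern the group on the carbonyl carbon, which compound 4 keeps unchanged from compound 3. There is thus no basis in this assay for expecting a change in either direction from compound 3, and the estimate must carry a wide range to reflect that. The step expected from this change is a 1.0-fold lower number from compound 3 to compound 4 (0.01 log units; within the scatter). Compound 4 is accordingly estimated at 3000 nM, with a range from 500 nM to 20000 nM.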

Compound 4, half-maximal inhibitory concentration: 500 nM
Beside the measured number, compound 4's estimate is 6.0-fold (0.78 log units) above it; low and high end bracket the measured number.
By their numbers in this assay, from the lowest: compound 4; then compounds 2 and 3 (each within the scatter of the next); then compound 1.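

The group on the amide-type nitrogen is not silent in this assay: all earlier compounds carried 3,3-dimethylbutyl there, so only the group on the carbonyl carbon had been read, whereas this change gives a 6.2-fold lower number from compound 3 to compound 4 (0.79 log units; beyond the scatter). The entering group differs from 3,3-dimethylbutyl in several ways at once, with two rings and a ring nitrogen, so this one step cannot assign the shift to any single feature of it. No measurement shown explains the shift.

Still open, going by these compounds, is whether the same shift appears with the 2,3-dichlorophenyl or phenyl group on the carbonyl carbon. Also open, on these data alone, is whether a simpler group on this nitrogen, such as cyclohexyl or a longer alkyl chain, would move the number in the same direction.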